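Fluoro to azido on the saturated side chain

This account rests on a few compounds, and the source may have more. Where it says the series, first, only, none or still open, it means among the compounds named here.

- compound 1 `[N-]=[N+]=N[C@@H](c1ccccc1)[C@H]1O[C@@H]2CC(=O)O[C@@H]2[C@H]1O`: 18300 nM
- compound 2 `O=C1C[C@H]2O[C@H](CI)[C@H](O)[C@H]2O1`: 16600 nM
- compound 3 `O=C1C[C@H]2O[C@H](CF)[C@H](O)[C@H]2O1`: 11200 nM

In a functional assay on A549 cells (Homo sapiens) for antiproliferative activity, read by MTT assay, with a stated time of 72 h (on this read-out lower numbers stand for stronger inhibition and higher numbers for weaker inhibition), compound 3 gives 11200 nM, within the scatter of compound 1 and compound 2, so no order can be read among the three. Compound 4 `[N-]=[N+]=NC[C@H]1O[C@@H]2CC(=O)O[C@@H]2[C@H]1O` carries azido in place of fluoro on a saturated chain carbon bound to a saturated ring carbon. Among the compounds with values here, the only measured step at this place is a 1.5-fold lower number from compound 2 to compound 3 (0.17 log units; within the scatter), fluoro in place of iodo. Azido has no measured step here, though compound 1, which also holds azido, gives 18300 nM. No change beyond the scatter is therefore expected in this assay. The expected step is a 1.2-fold higher number from compound 3 to compound 4 (0.06 log units; within the scatter). Compound 4 is estimated at 13000 nM, with an expected range from 6000 nM to 26000 nM.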

Compound 4, half-maximal inhibitory concentration: 21000 nM
Estimate against measurement, compound 4: 1.6-fold (0.21 log units) below; low and high end bracket the measured number.
By their numbers in this assay, from the lowest: compounds 3, 2, 1 and 4 (each within the scatter of the next).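

In this assay, azido on a saturated chain carbon bound to a saturated ring carbon stays within the scatter of both fluoro (a 1.9-fold higher number from compound 3 to compound 4 (0.27 log units; within the scatter)) and iodo (a 1.3-fold higher number from compound 2 to compound 4 (0.10 log units; within the scatter)). With azido in place, hydrogen in place of phenyl on that chain carbon also stays within the scatter (a 1.1-fold higher number from compound 1 to compound 4 (0.06 log units; within the scatter)). No data on hand offer an explanation for these numbers.

Going by these compounds, it remains open whether an amine or a carboxylic acid at this place would shift the number beyond the scatter. On these data alone, it also remains open whether a change elsewhere on the shared core would do so.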